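The source may hold more compounds than are shown below. What is called first, only, known or untested is meant among the compounds shown, and "the series" means these compounds.

Compound 1 `C#CCN(Cc1ccc2nc(C)nc(O)c2c1)c1ccc(C(=O)N[C@@H](CCC(=O)O)C(=O)N2CCCC2C(=O)O)cc1` gives 3100 nM in a functional assay (L1210 cells) for inhibition, with Mus musculus as the target (a higher number here means a weaker inhibitor, a lower number a stronger inhibitor), the highest of the three numbers in hand: compound 2 `C#CCN(Cc1cc2c(O)nc(C)nc2cc1C)c1ccc(C(=O)N[C@@H](CCC(=O)O)C(=O)N(CC#C)[C@@H](CCC(=O)O)C(=O)O)c(F)c1` gives 110 nM and compound 3 `C#CCN(Cc1cc2c(O)nc(C)nc2cc1C)c1ccc(C(=O)N[C@@H](CCC(=O)O)C(=O)N(CC)[C@@H](CCC(=O)O)C(=O)O)c(F)c1` gives 70 nM. Among the measured compounds shown here, the one step measured in a single place, a 1.6-fold lower number from compound 2 to compound 3 (0.20 log units; within the scatter), concerns a saturated chain carbon bound to an amide-type nitrogen and not the group exchanged here. Compound 4 `C#CCN(Cc1ccc2nc(C)nc(O)c2c1)c1ccc(C(=O)N[C@@H](CCC(=O)O)C(=O)N(C)[C@@H](CCC(=O)O)C(=O)O)cc1` carries (1,3-dicarboxypropyl)(methyl)amino in place of 2-carboxypyrrolidin-1-yl on a carbonyl carbon. For the measured compounds named here, no measured pair isolates this exchange; compounds 2 and 3 hold a (1,3-dicarboxypropyl)amino group together with further changes to the core, and both give far lower numbers than compound 1. On that basis the expected step is a 6.2-fold lower number from compound 1 to compound 4 (0.79 log units; beyond the scatter). Compound 4 is estimated at 500 nM, ranging from 100 nM to 2500 nM.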

Compound 4, half-maximal inhibitory concentration: 240 nM
Compound 4: middle estimate off by 2.1-fold (0.32 log units), on the high side; the measured number falls inside the stated range.
By their numbers in this assay, from the lowest: compounds 3 and 2 (each within the scatter of the next); then compound 4; then compound 1.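

In this assay, (1,3-dicarboxypropyl)(methyl)amino in place of 2-carboxypyrrolidin-1-yl on a carbonyl carbon gives a 13-fold lower number from compound 1 to compound 4 (1.11 log units; beyond the scatter). Among the compounds shown here, this is the first reading of that exchange on an unchanged core, so the large step no longer rests on compounds 2 and 3, whose cores differ from that of compound 1. No evidence on hand bears on the size of this step.

The exchange opens the ring and adds a carboxylic acid in one move, and the compounds shown do not separate the two. A (carboxymethyl)(methyl)amino group on the same carbonyl carbon would help to separate them.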